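A few compounds are considered here, and "the series" means these few. Any claim that something is new, unique, unknown or untested is made for them only; others in the source may bear on it.

Among the measured compounds shown here, compound 1 `N#Cc1ccc(NC(=S)N/N=C/c2ccc3ccccc3n2)cc1` is the only member of this set to yield a number in a functional assay on HL-60 cells (Homo sapiens) for antiproliferative activity, read by sulforhodamine B assay, with a stated time of 72 h; a lower number here means a stronger inhibitor, a higher number a weaker inhibitor: compound 1 gives 4660 nM. Compound 2 `Cc1ccc(NC(=O)N/N=C/c2ccc3ccccc3n2)cc1` returns only a limit of the assay, > 100000 nM. Compound 3 `NC(=S)N/N=C/c1cnc2ccccc2n1` likewise returns only a limit, > 100000 nM. Two of the three values thus sit at that limit (the limit of > 100000 nM in this assay, at which 2 of the 3 values shown sit), leaving compound 1 as the sole measured point. Compound 4 `S=C(N/N=C/c1ccc2ccccc2n1)Nc1ccc(Cl)cc1` differs from compound 1 in one place (chloro in place of cyano on an aromatic carbon). For the measured compounds named here, no step between measured compounds exists to calibrate this change, so the step from compound 1 to compound 4 is expected to stay within the usual scatter, with a slight lean toward stronger inhibition: a 1.3-fold lower number from compound 1 to compound 4 (0.12 log units; within the scatter). Compound 4 is therefore expected to give 3500 nM in this assay, between 1000 nM and 12000 nM.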

Compound 4, half-maximal inhibitory concentration: > 100000 nM
Compound 4: only a limit was reported; the forecaster's own chance of this, stated with the estimate: 10%; middle value at least 28-fold (1.45 log units) away from the limit.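

In this assay, the change from 4-cyanophenyl to 4-chlorophenyl gives an at least 21-fold higher number from compound 1 to compound 4 (1.33 log units; beyond the scatter). Among the compounds shown here, this is the first evidence that the group on this aromatic carbon, para to a large group, can decide whether the shared core gives a measurable number at all. The value of compound 4 is a limit and not a number, so the full size of the step stays unknown: the limit of > 100000 nM in this assay, at which 3 of the 4 values shown sit.

The compounds shown leave open whether the nitrile itself is required. They also leave open whether an amine, a methoxy group or a carboxylic acid at this place would preserve a measurable number.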